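Swapping bromo for cyano on a sulfonyl-bearing ring

The source may report more compounds than this note shows. Statements on the series, on what has been measured and on what is new or still open speak of the compounds shown alone.

Compound 1 `O=C1/C(=C/c2cccc(F)c2)CN(S(=O)(=O)c2ccc(Br)cc2)C/C1=C\c1cccc(F)c1` gives 11700 nM in a functional assay on SMMC-7721 cells (Homo sapiens) for cytotoxicity, read by MTT assay, with a stated time of 24 h; on this read-out lower numbers stand for stronger inhibition and higher numbers for weaker inhibition.
Compound 2 `N#Cc1ccc(S(=O)(=O)N2C/C(=C\c3cccc(F)c3)C(=O)/C(=C/c3cccc(F)c3)C2)cc1` gives 4500 nM in this assay.
Compound 3 `O=C1/C(=C/c2ccc(F)cc2)CN(S(=O)(=O)c2ccc(Br)cc2)C/C1=C\c1ccc(F)cc1` gives 11500 nM in this assay.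

Compound 1 and compound 3 share the same atoms joined differently; the difference between the two cores is not broken down here, and their two values lie within the scatter of one another. Compound 2 arises from compound 1 by one change, (cyano in place of bromo on an aromatic carbon), and that change made a 2.6-fold lower number from compound 1 to compound 2 (0.41 log units; beyond the scatter). Compound 4 `N#Cc1ccc(S(=O)(=O)N2C/C(=C\c3ccc(F)cc3)C(=O)/C(=C/c3ccc(F)cc3)C2)cc1`, not yet measured, arises from compound 3 by the same change, (cyano in place of bromo on an aromatic carbon), at the same place. Because compound 1 gives 11700 nM and compound 3 gives 11500 nM in this assay, the step to compound 4 is expected to resemble the earlier one, a 2.6-fold lower number from compound 3 to compound 4 (0.42 log units; beyond the scatter). Compound 4 is therefore estimated at 4400 nM, expected between 2200 nM and 9000 nM.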

Compound 4, half-maximal inhibitory concentration: 15000 nM
Compound 4: middle estimate off by 3.4-fold (0.53 log units), on the low side; the whole stated range lies below it.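

On the core of compound 3, cyano in place of bromo gave a 1.3-fold higher number from compound 3 to compound 4 (0.12 log units; within the scatter), so in this assay these two compounds cannot be told apart. The same change therefore did not carry over from one core to the other: the same change on two cores in this assay, a 2.6-fold lower number (0.41 log units; beyond the scatter) from compound 1 to compound 2 and a 1.3-fold higher number (0.12 log units; within the scatter) from compound 3 to compound 4, 3.4-fold (0.53 log units) apart, beyond the scatter of two such steps This shows that a step measured on one core cannot safely be assumed on the other, even when the two bromo compounds read alike; it does not show why the two cores part ways, and one pair per core cannot say how other cores would respond.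

The compounds shown leave open whether another group in the same place, such as an amine or a carboxylic acid, would also differ between the two cores. Also open, going by these compounds, is whether the gap would remain with methoxy groups in place of the fluoro groups.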